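Trimethoxyphenyl for methoxyphenyl on the pyrazoline series

The source may report more compounds than this note shows. Statements on the series, on what has been measured and on what is new or still open speak of the compounds shown alone.

Compound 1 `COc1ccc(C2=NN(C(=O)c3cccnc3)C(c3cn(C)c4ccc(Br)cc34)C2)cc1` and compound 2 `COc1cc(C2=NN(C(=O)c3cccnc3)C(c3cn(C)c4ccc(Br)cc34)C2)cc(OC)c1OC` share one core; compound 3 `COc1ccc(C2=NN(C(=O)c3ccc(OC)nc3)C(c3cn(C)c4ccc(OC)cc34)C2)cc1` and compound 4 `COc1ccc2c(c1)c(C1CC(c3cc(OC)c(OC)c(OC)c3)=NN1C(=O)c1ccc(OC)nc1)cn2C` share another, and the difference between the two cores is not broken down here. In a functional assay on HeLa cells (Homo sapiens) for inhibition, read by MTT assay, with a stated time of 48 h (on this read-out higher numbers stand for weaker inhibition of growth and lower numbers for stronger inhibition of growth), compound 1 gives 890 nM. Compound 2 gives only a limit in this assay, namely > 10000 nM, which is the limit of > 10000 nM in this assay, at which 1 of the 3 values shown sits. The change from compound 1 to compound 2 is 3,4,5-trimethoxyphenyl in place of 4-methoxyphenyl on a carbon with a double bond to nitrogen, and it made an at least 11-fold higher number from compound 1 to compound 2 (1.05 log units; beyond the scatter). In this assay compound 3 gives 180 nM, the lower of the two numbers, and its gap to compound 1 is beyond the scatter.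

Compound 4 is not yet measured in this assay. It differs from compound 3 by 3,4,5-trimethoxyphenyl in place of 4-methoxyphenyl on a carbon with a double bond to nitrogen. For the measured compounds named here, this is the same kind of change as the one from compound 1 to compound 2, not the same: around the place, compound 3 and compound 4 carry a (6-methoxypyridin-3-yl)carbonyl group two ring bonds from the changed carbon, where compound 1 and compound 2 carry a (pyridin-3-yl)carbonyl group there.

For compound 4 the expected value in this assay is 2500 nM, with a range from 600 nM to 10000 nM. This estimate means a step of a 14-fold higher number from compound 3 to compound 4 (1.14 log units; beyond the scatter), expected to sit beside an at least 11-fold higher number from compound 1 to compound 2 (1.05 log units; beyond the scatter); that earlier step is known only as a limit, which leaves its true size open and widens the range here.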

Compound 4, concentration for 50% growth inhibition: > 10000 nM
Compound 4: a limit, no number; the forecaster's own chance of this, stated with the estimate: 20%; at least 4.0-fold (0.60 log units) between middle value and limit.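

In this assay compound 4 gives only a limit, > 10000 nM, and not a number. Placing 3,4,5-trimethoxyphenyl where 4-methoxyphenyl stood on a carbon with a double bond to nitrogen gave an at least 55-fold higher number from compound 3 to compound 4 (1.74 log units; beyond the scatter), so on both cores shown the change moved the read-out towards weaker inhibition of growth, by a step beyond the scatter. This holds for these two pairs only, and no difference in the size of the step between the two cores can be claimed: the same change on two cores in this assay, an at least 11-fold higher number (1.05 log units; beyond the scatter) from compound 1 to compound 2 and an at least 55-fold higher number (1.74 log units; beyond the scatter) from compound 3 to compound 4; the limit leaves it open whether they differ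

Still open, as far as these compounds go, is how the read-out responds to groups at this place other than these two, for example an unsubstituted phenyl, a dimethoxyphenyl or a 4-ethoxyphenyl, which could show whether one methoxy group or the full set of three accounts for the step. How weak compound 2 and compound 4 really are also stays unknown, and no order can be given for the two: the limit of > 10000 nM in this assay, at which 2 of the 4 values shown sit.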